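A few compounds are considered here, and "the series" means these few. Any claim that something is new, unique, unknown or untested is made for them only; others in the source may bear on it.

Measured compounds:
compound 1 `CC1=NN(C(=O)COc2ccc(Cl)cc2)C(c2cc(Br)cc(Br)c2O)C1` — 40200 nM
compound 2 `COc1ccccc1C1CC(C)=NN1C(=O)C[N+]1(C)CCCC1` — 11200 nM
compound 3 `O=C(c1ccccc1Cl)N1N=C(c2cc3ccccc3oc2=O)CC1c1ccccc1` — 6370 nM

All three numbers come from a functional assay on PC-3 cells (Homo sapiens) for cytotoxicity, read by MTT assay, with a stated time of 48 h; a higher number here means a weaker inhibitor, a lower number a stronger inhibitor. Compound 3 gives the lowest of the three numbers shown, but compound 2 sits within the usual scatter of it, so the two cannot be ranked against each other; only compound 1 lies clearly beyond compound 3.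

Compound 4 `CC1CC(C)CN(CC(=O)N2N=C(c3cc4ccccc4oc3=O)CC2c2ccccc2)C1` is not yet measured. It differs from compound 3 in one place: (3,5-dimethylpiperidin-1-yl)methyl in place of 2-chlorophenyl on a carbonyl carbon. Among the measured compounds shown here, no pair among the measured compounds differs in one place, so the size of such a step has no precedent here. For the measured compounds named here, compound 2, which also carries a saturated amine ring on the carbonyl carbon, gives a number within the scatter of compound 3, and that is the only guide the set offers.

The expectation for compound 4 in this assay is therefore a step of no more than the scatter, leaning toward a slightly higher number, a 1.4-fold higher number from compound 3 to compound 4 (0.15 log units; within the scatter). The estimated value for compound 4 is 9000 nM, with a range from 3000 nM to 30000 nM.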

Compound 4, half-maximal inhibitory concentration: "not active" (no number reported)
For compound 4 the study gives words and no number, so the estimate cannot be set against anything.
By their numbers in this assay, from the lowest: compounds 3 and 2 (each within the scatter of the next); then compound 1.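

Among the compounds shown here, compound 4 is reported as "not active" in this assay with no number, so no step from compound 3 to compound 4 can be read. Nothing shown accounts for this result. The compounds shown leave open how large the change from 2-chlorophenyl to (3,5-dimethylpiperidin-1-yl)methyl is in this assay.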